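Butyl Homologation on Two Cores: Lipophilicity Notes

A few compounds are considered here, and "the series" means these few. Any claim that something is new, unique, unknown or untested is made for them only; others in the source may bear on it.

Compound 1 `CCCN(C)/N=N/c1ccc(C(=O)O)cc1` and compound 2 `CCCCCCCN(C)/N=N/c1ccc(C(=O)O)cc1` share one core. In a physicochemical assay for lipophilicity (on this read-out higher numbers stand for higher lipophilicity and lower numbers for lower lipophilicity), compound 1 gives 0.46, and compound 2 gives 2.58. The step between them, a number 2.12 log units higher from compound 1 to compound 2 (beyond the scatter), goes with the structural change (butyl in place of hydrogen on a saturated chain carbon, three bonds along the chain from an amine nitrogen).

Compound 3 `CCCCN(C)/N=N/c1ccc(C(N)=O)cc1` stands on a different core; the difference between the two cores is not broken down here. In this assay compound 3 gives 2.46, which lies close to the number for compound 2 and well apart from the number for compound 1.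

Compound 4 `CCCCCCCCN(C)/N=N/c1ccc(C(N)=O)cc1` has not yet been measured. Against compound 3 it shows the change (butyl in place of hydrogen on a saturated chain carbon, four bonds along the chain from an amine nitrogen). Among the measured compounds shown here, this is the same kind of change as the one from compound 1 to compound 2, not the same change: there the butyl enters on a saturated chain carbon three bonds along the chain from an amine nitrogen, here on a saturated chain carbon four bonds along the chain from an amine nitrogen. Only two instances of this kind of change occur among the compounds shown, so the expectation rests on a single measured step.

In this assay the step is expected to be a number 2.14 log units higher from compound 3 to compound 4 (beyond the scatter), resting on the measured step of a number 2.12 log units higher from compound 1 to compound 2 (beyond the scatter) for the same kind of change. The estimated value for compound 4 is 4.6. The expected range for compound 4 runs from 4.1 to 5.1.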

Compound 4, partition coefficient: 4.7
For compound 4 the middle estimate is 0.10 log units below the measured one, and the stated range covers the measured number.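

Working notes: the butyl change carries over between the two cores shown. In this assay the read-out rises by a number 2.24 log units higher from compound 3 to compound 4 (beyond the scatter) on one core and by a number 2.12 log units higher from compound 1 to compound 2 (beyond the scatter) on the other, so both steps run in the same direction, both are large and both lie beyond the scatter. Among the compounds shown here, this is still only two pairs, with the butyl entering four bonds along the chain from an amine nitrogen in the first and three bonds along in the second, so the notes show agreement on these two cores and give no rule for any third core or for any other point of attachment. Nothing at hand bears on why the step has this size on either core.

Open, on these data alone, is whether a hydroxyl or an amine carried on the butyl would give a step of similar size on these cores, or whether a phenyl ring in place of the butyl would do so. Also open is whether a chain longer than those shown would continue to add to the number in this assay in the same way on both cores.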